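The source may report more compounds than this note shows. Statements on the series, on what has been measured and on what is new or still open speak of the compounds shown alone.

Measured so far in an assay on CHO cells for positive allosteric modulation of metabotropic glutamate receptor 5 (Rattus norvegicus), read by FLIPR; a higher number here means that more compound is needed for the effect, a lower number that less compound is needed:

Compound 1 `O=C(Nc1ccc(Cl)cc1CN1C(=O)c2ccccc2C1=O)c1ccccc1[N+](=O)[O-]` gives < 1000 nM, a limit of the assay.
Compound 2 `O=C(Nc1ccc(Cl)cc1CN1C(=O)c2ccccc2C1=O)c1ccccc1C(F)(F)F` gives < 1000 nM, a limit of the assay.
Compound 3 `O=C(Nc1ccc(Cl)cc1CN1C(=O)c2ccccc2C1=O)c1ncccc1O` gives < 1000 nM, a limit of the assay.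

Compound 3 thus stands at the limit where every value shown sits (the limit of < 1000 nM in this assay, at which 3 of the 3 values shown sit). The steps a step that the two limits leave unreadable from compound 1 to compound 2, a step that the two limits leave unreadable from compound 1 to compound 3 and a step that the two limits leave unreadable from compound 2 to compound 3 are therefore of unreadable size. Compound 4 `COc1ccccc1C(=O)Nc1ccc(Cl)cc1CN1C(=O)c2ccccc2C1=O` differs from compound 3 by 2-methoxyphenyl in place of 3-hydroxypyridin-2-yl on a carbonyl carbon. The measured steps bear on this only in that none of the three changes at this carbonyl carbon carried a value out from under the limit. Compound 4 is expected to behave alike, with a step that the limit leaves unreadable from compound 3 to compound 4 in this assay estimated to stay within the scatter. Compound 4 is estimated at 300 nM, within 50 nM to 1500 nM.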

Compound 4, half-maximal effective concentration: < 1000 nM
Compound 4: a limit, no number; the forecaster's own chance of this, stated with the estimate: 65%; the middle value does not contradict the limit.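

Among the compounds shown here, compound 4 joins compound 1, compound 2 and compound 3 at a limit of this assay, so no step among them can be read: the limit of < 1000 nM in this assay, at which 4 of the 4 values shown sit. The compounds shown leave open how far apart their true values lie, and whether the changes at the carbonyl carbon matter at all.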